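This account rests on a few compounds, and the source may have more. Where it says the series, first, only, none or still open, it means among the compounds named here.

In a functional assay on thoracic aorta (Rattus norvegicus, strain Wistar), with a stated time of 15 min (on this read-out lower numbers stand for an effect already at smaller amounts and higher numbers for an effect only at larger amounts of compound), compound 1 `COc1ccc(F)cc1C(C)NC(=O)N(C)S(=O)(=O)c1ccc(Cl)cc1` gives 12600 nM, compound 2 `COc1ccc(Cl)cc1C(C)NC(=O)N(C)S(=O)(=O)c1ccccc1` gives 7200 nM and compound 3 `CCOc1ccc(F)cc1C(C)NC(=O)N(C)S(=O)(=O)c1ccccc1` gives 11500 nM. Compound 3 thus stands within the scatter of both other compounds, and these three values do not separate them. Compound 4 `COc1ccc(F)cc1C(C)NC(=O)N(C)S(=O)(=O)c1ccccc1` has not yet been measured. It has hydrogen in place of methyl on a saturated chain carbon bound to an oxygen on an aromatic ring, turning ethoxy to methoxy. No measured pair of these compounds differs in one place alone, so this change has no direct precedent here. Compound 1 at 12600 nM and compound 2 at 7200 nM both carry methoxy, differ from compound 3 elsewhere as well, and remain within the scatter of it. In this assay, the step of a 1.2-fold lower number from compound 3 to compound 4 (0.06 log units; within the scatter) is therefore expected to stay within the scatter, with no firm direction. For compound 4 the estimated value is 10000 nM, with an expected range from 5000 nM to 20000 nM.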

Compound 4, half-maximal effective concentration: 10000 nM
Compound 4: the middle estimate sits on the measured number at the digits printed, and the stated range covers the measured number.
By their numbers in this assay, from the lowest: compounds 2, 4, 3 and 1 (each within the scatter of the next).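

Among these compounds, with compound 4, single-place comparisons become possible in this assay for the first time. The step of a 1.2-fold lower number from compound 3 to compound 4 (0.06 log units; within the scatter) goes with hydrogen in place of methyl on a saturated chain carbon bound to an oxygen on an aromatic ring, so ethoxy and methoxy are not told apart at this position. The steps of a 1.4-fold higher number from compound 2 to compound 4 (0.14 log units; within the scatter) for fluoro in place of chloro and a 1.3-fold lower number from compound 1 to compound 4 (0.10 log units; within the scatter) for hydrogen in place of chloro, each on an aromatic carbon, likewise leave these changes unresolved, and no supporting evidence bears on these results.

The compounds shown leave open whether a longer chain such as propoxy or butoxy on that oxygen would give a number beyond the scatter. They also leave open whether an amine or a carboxylic acid on an aromatic carbon would do so.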